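The compounds below may be only part of what the source reports. "The series", "measured", "known", "first", "only" and "open" are said of these compounds alone.

Three compounds have been measured in a functional assay on HeLa cells (Homo sapiens) for inhibition, read by CCK-8 assay, with a stated time of 72 h, tested at 2 uM; on this read-out higher numbers stand for more inhibition of growth at the one concentration tested and lower numbers for less inhibition of growth:

Compound 1 `Nc1ccccc1NC(=O)c1ccc(CSc2ccc(Br)cc2)cc1` gives 18.8%.
Compound 2 `COc1ccc(SCc2ccc(C(=O)Nc3ccccc3N)cc2)cc1` gives 35%.
Compound 3 `Nc1ccccc1NC(=O)c1ccc(CSc2ccc(Cl)cc2)cc1` gives 19.2%.

Compound 2 stands highest of the three in this assay. Its nearest neighbour is compound 3, reached by a number 15.8 percentage points lower from compound 2 to compound 3 (beyond the scatter), and compound 1 lies furthest, as a number 16.2 percentage points higher from compound 1 to compound 2 (beyond the scatter) shows. The two halogen compounds sit together, since a number 0.4 percentage points higher from compound 1 to compound 3 (within the scatter) is within the scatter.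

The step to compound 4 `COc1ccc(SCc2ccc(C(=O)Nc3ccccc3N)cc2)cc1OC` starts from compound 2 and brings (methoxy in place of hydrogen on an aromatic carbon). For the measured compounds named here, no measured pair touches this position; the three measured steps all concern exchanges of the single group already present, so they bear on the new step only indirectly. They show that a methoxy group in place of either halogen went with a modestly higher number in this assay, and that the two halogens did not differ beyond the scatter. Whether a second methoxy group ortho to the first adds anything beyond the scatter cannot be read from these three compounds. Compound 4 is expected to differ from its parent by a number 3 percentage points higher from compound 2 to compound 4 (within the scatter), a step that may well fall within the scatter. The estimate for compound 4 is 38%, with a range from 20% to 58%.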

Compound 4, percent growth inhibition at one concentration: 15.2%
Beside the measured number, compound 4's estimate is 22.8 percentage points above it; measured number below the stated range.
By their numbers in this assay, from the lowest: compounds 4, 1 and 3 (each within the scatter of the next); then compound 2.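

In this assay, for the compounds shown here, a methoxy group in place of hydrogen, ortho to the methoxy group of compound 2, gave a number 19.8 percentage points lower from compound 2 to compound 4 (beyond the scatter) and so showed that this position, which no earlier compound touched, is sensitive to this change. The earlier steps shown here had linked a single methoxy group, in place of either halogen, to a higher number, but this step shows that a second methoxy group on the same ring does not extend that rise and instead goes with a lower number. Nothing measured here accounts for the drop, so the step stands as an observation without an explanation.

The compounds shown leave open whether the lower number belongs to methoxy in particular or would follow any group at this carbon, such as a hydroxy group, a fluorine atom or an amine. They also leave open whether a methoxy group at this position would go with the same change when bromo or chloro takes the place of the first methoxy group.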